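Ring size at the ester oxygen: cyclopentyl to cyclohexyl

The compounds below may be only part of what the source reports. "The series", "measured", "known", "first", "only" and "open" are said of these compounds alone.

Compound 1 `COC(=O)C1=C(C)NC(C)=C(C(=O)OC)C1c1csc(-c2ccc(Cl)cc2)n1`: 4430 nM
Compound 2 `CCOC(=O)C1=C(C)NC(C)=C(C(=O)OC)C1c1csc(-c2ccc(Cl)cc2)n1`: 22000 nM
Compound 3 `COC(=O)C1=C(C)NC(C)=C(C(=O)OC2CCCC2)C1c1csc(-c2ccc(Cl)cc2)n1`: 7290 nM

In an assay on isolated protein for antagonist activity at Voltage-dependent L-type calcium channel subunit alpha-1C (Cavia porcellus), with a stated time of 15 min (on this read-out lower numbers stand for stronger inhibition and higher numbers for weaker inhibition), compound 3 stands second highest of the three numbers, with compound 1 nearest (a 1.6-fold higher number from compound 1 to compound 3 (0.22 log units; within the scatter)) and compound 2 furthest (a 3.0-fold lower number from compound 2 to compound 3 (0.48 log units; beyond the scatter)). The step from compound 1 to compound 2 was a 5.0-fold higher number from compound 1 to compound 2 (0.70 log units; beyond the scatter). Compound 4 `COC(=O)C1=C(C)NC(C)=C(C(=O)OC2CCCCC2)C1c1csc(-c2ccc(Cl)cc2)n1` differs from compound 3 only in one place: cyclohexyl in place of cyclopentyl on an oxygen next to a carbonyl group. Within the data shown here, no measured step adds one carbon to a ring at this oxygen; the nearest guides are the steps from compound 1 and compound 2 to compound 3, which show that changes at this oxygen have stayed modest. Compound 4 is therefore expected to give 8000 nM in this assay, a step of a 1.1-fold higher number from compound 3 to compound 4 (0.04 log units; within the scatter), with a range from 3500 nM to 18000 nM.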

Compound 4, half-maximal inhibitory concentration: 71900 nM
Compound 4: the middle estimate sits 9.0-fold (0.95 log units) below what was measured; the measured number lies above the stated range.
By their numbers in this assay, from the lowest: compounds 1 and 3 (each within the scatter of the next); then compound 2; then compound 4.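

In this assay, among these compounds, this oxygen proved far less forgiving than the earlier compounds suggested, with a 9.9-fold higher number from compound 3 to compound 4 (0.99 log units; beyond the scatter) exceeding every earlier step at the position. Cyclohexyl also stands apart from the smaller groups, with a 3.3-fold higher number from compound 2 to compound 4 (0.51 log units; beyond the scatter) and a 16-fold higher number from compound 1 to compound 4 (1.21 log units; beyond the scatter), yet the numbers do not climb steadily with group size, since ethyl goes against that order by sitting above cyclopentyl. Nothing available accounts for the jump between the two rings.

As far as these compounds go, whether a cyclobutyl ring, a phenyl ring or a longer chain ending in an amine at this oxygen would track cyclopentyl or cyclohexyl remains open.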